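The compounds below may be only part of what the source reports. "The series", "measured", "known", "first", "only" and "open" are said of these compounds alone.

Measured in a functional assay on MCF7 cells (Homo sapiens) for antiproliferative activity; a lower number here means a stronger inhibitor, a higher number a weaker inhibitor:
- compound 1 `COc1cccc(Oc2ccc3cc(NC(=O)c4ccc(OC(C)=O)c(CC=C(C)C)c4)c(=O)oc3c2C)c1`: 15700 nM
- compound 2 `COc1cccc(Oc2ccc3cc(NC(=O)c4ccc(O)c(CC=C(C)C)c4)c(=O)oc3c2C)c1`: 62800 nM
- compound 3 `COc1ccc(Nc2ccc3cc(NC(=O)c4ccc(O)c(CC=C(C)C)c4)c(=O)oc3c2C)cc1`: > 100000 nM

The entry for compound 3 is a limit of the assay, not a number. Compound 1 has the lower of the two numeric values. Hydrogen in place of acetyl gives a 4.0-fold higher number from compound 1 to compound 2 (0.60 log units; beyond the scatter).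

Compound 4 `COCOc1ccc(Cc2ccc3cc(NC(=O)c4ccc(OC(C)=O)c(CC=C(C)C)c4)c(=O)oc3c2C)cc1` keeps that acetyl. The change is 4-(methoxymethoxy)benzyl in place of 3-methoxyphenoxy on an aromatic carbon, with 4-(methoxymethoxy)benzyl in place of 3-methoxyphenoxy. The nearest measured change at this carbon is an at least 1.5-fold higher number from compound 2 to compound 3 (0.20 log units; that floor lies within the scatter), so only a small rise in the number is expected, with wide uncertainty. The expected step is a 1.6-fold higher number from compound 1 to compound 4 (0.20 log units; within the scatter). For compound 4 the estimate is 25000 nM, with an expected range of 7000 nM to 90000 nM.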

Compound 4, half-maximal inhibitory concentration: 22700 nM
Compound 4: the middle estimate sits 1.1-fold (0.04 log units) above what was measured; the measured number falls inside the stated range.
By their numbers in this assay, from the lowest: compounds 1 and 4 (each within the scatter of the next); then compound 2. At a limit, above all of these: compound 3.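

In this assay, 4-(methoxymethoxy)benzyl in place of 3-methoxyphenoxy on this aromatic carbon gives a 1.4-fold higher number from compound 1 to compound 4 (0.16 log units; within the scatter). Among these compounds, this gives the first numeric step at this carbon, and it shows that, with the acetyl kept, this exchange of substituents moves the number by no more than the usual scatter. The earlier change here, to (4-methoxyphenyl)amino in compound 3, ends at a limit of the assay rather than a number: the limit of > 100000 nM in this assay, at which 1 of the 4 values shown sits.

On these data alone, whether hydrogen in place of acetyl gives a similar step with 4-(methoxymethoxy)benzyl present remains open. As far as these compounds go, the effect of an amine or a carboxylic acid on this carbon also remains open.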